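Cytotoxicity notes on a sulfonamide pair with catechol replacing dinitro

The compounds below may be only part of what the source reports. "The series", "measured", "known", "first", "only" and "open" are said of these compounds alone.

Measured compounds:
Compound 1 `O=C(Nc1cccc([N+](=O)[O-])c1)N1CCN(S(=O)(=O)c2sccc2-c2ccccc2Oc2ccc(O)c(O)c2)CC1`: > 20000 nM
Compound 2 `O=C(NCCNS(=O)(=O)c1ccc(-c2ccccc2Oc2ccc([N+](=O)[O-])c([N+](=O)[O-])c2)s1)Nc1cc(C(F)(F)F)cc(C(F)(F)F)c1`: > 50000 nM

In an ADME assay on HEK-293T cells (Homo sapiens) for cytotoxicity, read by CCK-8 assay, with a stated time of 48 h (a higher number here means a weaker inhibitor, a lower number a stronger inhibitor), compound 2 gives > 50000 nM, which is a limit of the assay and not a number. Compound 1 likewise reaches only a limit, > 20000 nM. Compound 3 `O=C(NCCNS(=O)(=O)c1ccc(-c2ccccc2Oc2ccc(O)c(O)c2)s1)Nc1cc(C(F)(F)F)cc(C(F)(F)F)c1` is not yet measured; it differs from compound 2 by 3,4-dihydroxyphenyl in place of 3,4-dinitrophenyl on an oxygen on an aromatic ring. For the measured compounds named here, both measured values sit at limits (the limit of > 20000 nM in this assay, at which 1 of the 2 values shown sits, (the limit of > 50000 nM in this assay, at which 1 of the 2 values shown sits)), so no measured step can be sized. No step beyond the scatter is expected in this assay: a step that the limit leaves unreadable from compound 2 to compound 3. Compound 3 is estimated at 60000 nM, within 20000 nM to 200000 nM, and is expected most likely to be reported again as a limit.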

Compound 3, half-maximal inhibitory concentration: 17100 nM
For compound 3 the middle estimate is 3.5-fold (0.55 log units) above the measured one; measured number below the stated range.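

In this assay, 3,4-dihydroxyphenyl in place of 3,4-dinitrophenyl on an oxygen on an aromatic ring gives an at least 2.9-fold lower number from compound 2 to compound 3 (0.46 log units; beyond the scatter). For the compounds shown here, this is the first sign that the group at this position can move the read-out, and compound 3 gives a real number, 17100 nM, rather than a limit. The full size of the step stays unknown, as its starting point is only a limit: the limit of > 50000 nM in this assay, at which 1 of the 3 values shown sits.

Going by these compounds, it remains open which of the two hydroxyl groups carries the step. Also open, on these data alone, is whether a phenyl ring bearing an amine or a carboxylic acid would read differently in this assay.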